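Moving the nitro group of compound 2

A few compounds are considered here, and "the series" means these few. Any claim that something is new, unique, unknown or untested is made for them only; others in the source may bear on it.

In a functional assay on HT-29 cells (Homo sapiens) for cytotoxicity, read by sulforhodamine B assay (a higher number here means a weaker inhibitor of growth, a lower number a stronger inhibitor of growth), compound 1 `CC1=CC[C@@H]([C@@](C)(O)CCCC(C)(C)NC(=S)N/N=C\c2ccc(O)cc2)CC1` gives 8150 nM and compound 2 `CC1=CC[C@@H]([C@@](C)(O)CCCC(C)(C)NC(=S)N/N=C\c2cccc([N+](=O)[O-])c2)CC1` gives 14100 nM so the two stand within the scatter of each other. Compound 3 `CC1=CC[C@@H]([C@@](C)(O)CCCC(C)(C)NC(=S)N/N=C\c2ccc([N+](=O)[O-])cc2)CC1` changes one thing (4-nitrophenyl in place of 3-nitrophenyl on a carbon with a double bond to nitrogen) with 4-nitrophenyl in place of 3-nitrophenyl on a carbon with a double bond to nitrogen. Within the data shown here, the only measured step at that place (a 1.7-fold higher number from compound 1 to compound 2 (0.24 log units; within the scatter)) swapped 4-hydroxyphenyl for 3-nitrophenyl and stayed small, so no change beyond the scatter is expected. The expected step in this assay (a 1.2-fold lower number from compound 2 to compound 3 (0.07 log units; within the scatter)) therefore lies within the scatter. The estimate for compound 3 is 12000 nM (expected range 6000 nM to 24000 nM).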

Compound 3, concentration for 50% growth inhibition: 12300 nM
Compound 3: middle estimate off by 1.0-fold (0.01 log units), on the low side; the measured number falls inside the stated range.
By their numbers in this assay, from the lowest: compounds 1, 3 and 2 (each within the scatter of the next).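

In this assay, moving the nitro group from 3-nitrophenyl to 4-nitrophenyl leaves the result unchanged within the scatter (a 1.1-fold lower number from compound 2 to compound 3 (0.06 log units; within the scatter)). Compound 3 also gives a direct swap of nitro for hydroxy on an aromatic carbon, and this too stays within the scatter (a 1.5-fold higher number from compound 1 to compound 3 (0.18 log units; within the scatter)). Nothing available explains why these changes are so small.

Still open, as far as these compounds go, is whether an amine or a carboxylic acid on that aromatic carbon would produce a step beyond the scatter. From the compounds shown here alone, the effect of changes elsewhere on the shared core also remains unknown.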